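This account rests on a few compounds, and the source may have more. Where it says the series, first, only, none or still open, it means among the compounds named here.

Measured so far in an ADME assay on microsomes from liver (Homo sapiens) for pharmacokinetics, read by LC-MS, with a stated time of 60 min, tested at 1 uM (a higher number here means faster removal of the compound, a lower number slower removal), here:
- compound 1 `O=C(NCc1ccc(S(=O)(=O)c2cccc(C(F)(F)F)c2)cc1)N1Cc2ccncc2C1` gives 14 mL/min/kg
- compound 2 `CC(C)n1cc(S(=O)(=O)c2ccc(CNC(=O)N3Cc4ccncc4C3)cc2)cn1` gives 4 mL/min/kg

Compound 2 holds the lower of these two numbers. Compound 3 `O=C(NCc1ccc(S(=O)(=O)C2CCCCC2)cc1)N1Cc2ccncc2C1` has cyclohexyl in place of 1-isopropyl-1H-pyrazol-4-yl on a sulfonyl sulfur, and cyclohexyl has not been measured in this set. Among the compounds with values here, the one measured step on that sulfur is a 3.5-fold lower number from compound 1 to compound 2 (0.54 log units; beyond the scatter) and it brought in the group now leaving, so a move back upward of similar or smaller size seems likely. The expected change is an estimated 2.3-fold higher number from compound 2 to compound 3 (0.35 log units; beyond the scatter) in this assay on this single precedent. Compound 3 is estimated at 9 mL/min/kg with 4 mL/min/kg to 20 mL/min/kg as the expected range.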

Compound 3, clearance: 16 mL/min/kg
The estimate for compound 3 lay 1.8-fold (0.25 log units) below the measured number; the measured number falls inside the stated range.
By their numbers in this assay, from the lowest: compound 2; then compounds 1 and 3 (each within the scatter of the next).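

In this assay, replacing 1-isopropyl-1H-pyrazol-4-yl with cyclohexyl on the sulfonyl sulfur gives a 4.0-fold higher number from compound 2 to compound 3 (0.60 log units; beyond the scatter) and so loses the low number of compound 2. Against the 3-(trifluoromethyl)phenyl group, cyclohexyl gives a 1.1-fold higher number from compound 1 to compound 3 (0.06 log units; within the scatter) so on this sulfur only the pyrazole group stands apart so far. Nothing available here explains this difference. On these data alone, it remains open whether the pyrazole ring or its isopropyl group matters more, and whether a morpholine ring or a pyridine ring on this sulfur would also give a low number.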